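This account rests on a few compounds, and the source may have more. Where it says the series, first, only, none or still open, it means among the compounds named here.

For the measured compounds named here, compound 3, `Cc1cc(C(=O)Nc2c(F)cccc2F)nn1Cc1cc(Cl)ccc1OCc1ccccc1`, is one of three compounds measured in an assay on CHO-K1 cells for displacement of a labelled ligand from prostaglandin E2 receptor EP1 subtype (Homo sapiens); a lower number here means a stronger inhibitor, a higher number a weaker inhibitor. Compound 3 gives 10 nM, the same digits as compound 2, `Cc1cc(C(=O)O)nn1C(C)c1cc(Cl)ccc1OCc1ccccc1`, which gives 10 nM. Compound 1, `Cc1cc(C(=O)O)nn1Cc1cc(Br)ccc1OCc1ccccc1`, gives 6.31 nM, and its gap to compound 3 lies within the scatter, so the three numbers are read as one level.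

Compound 4, `Cc1cc(NC(=O)C2CCCO2)nn1Cc1cc(Cl)ccc1OCc1ccccc1`, has not yet been measured. It differs from compound 3 in one place: ((oxolan-2-yl)carbonyl)amino in place of (2,6-difluorophenyl)carbamoyl on an aromatic carbon. The (2,6-difluorophenyl)carbamoyl group leaves and a ((oxolan-2-yl)carbonyl)amino group enters, on an aromatic carbon of a five-membered aromatic ring with 2 nitrogen, next to the ring nitrogen. Going by the values given here, no measured pair in this set shows a step of this kind, so the size of the step rests on judgement alone. In compounds 1, 2 and 3 a carbonyl sits directly on that carbon; in compound 4 a nitrogen sits there instead, so a step toward a higher number in this assay, beyond the scatter but modest, is expected: a 3.0-fold higher number from compound 3 to compound 4 (0.48 log units; beyond the scatter). Compound 4 is expected to give 30 nM, with a range from 8 nM to 150 nM.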

Compound 4, half-maximal inhibitory concentration: 39.8 nM
Beside the measured number, compound 4's estimate is 1.3-fold (0.12 log units) below it; measured number inside the range.
By their numbers in this assay, from the lowest: compounds 1, 2 and 3 (each within the scatter of the next); then compound 4.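

For the compounds shown here, with compound 4, a nitrogen rather than a carbonyl sits for the first time on the aromatic carbon next to the ring nitrogen, and in this assay the change costs only a 4.0-fold higher number from compound 3 to compound 4 (0.60 log units; beyond the scatter), a modest step. A carbonyl directly on that carbon is therefore not needed for compound 4 to register in this assay, and the six-membered aromatic ring of carbon only can be absent from this substituent, with an oxolane ring present instead. No measurement here gives a reason for the size of this step.

The step combines two changes, the atom on the ring carbon and the ring at the end of the substituent, so the compounds shown cannot divide it between them. A (2,6-difluorobenzoyl)amino group or an (oxolan-2-yl)carbamoyl group at this position would tell the two apart.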